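Side-group variation on the shared core: compound 4 awaited

The source may report more compounds than this note shows. Statements on the series, on what has been measured and on what is new or still open speak of the compounds shown alone.

Measured so far:
compound 1 `CC/C=C\C[C@H]1C(=O)C=C[C@H]1CC(=O)Oc1ccc(O)cc1`: 23000 nM
compound 2 `CC/C=C\C[C@H]1C(=O)C=C[C@H]1CC(=O)Oc1ccccc1OC`: 32000 nM
compound 3 `CC/C=C\C[C@H]1C(=O)C=C[C@H]1CC(=O)OC(C)c1ccccc1`: 18000 nM

In a functional assay on RAW264.7 cells (Mus musculus) for inhibition, read by ELISA, with a stated time of 24 h (a lower number here means that less compound is needed, a higher number that more compound is needed for the effect), compound 1 gives 23000 nM. On the numbers shown, compound 1 stands between compound 3 and compound 2, but both of those neighbours lie within the scatter of compound 1, so the three compounds cannot be told apart and no order among them is claimed. The three differ only in the group on the oxygen next to the carbonyl group, and none of these variations has moved the number beyond the scatter.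

Compound 4 `CC/C=C\C[C@H]1C(=O)C=C[C@H]1CC(=O)OC1CCCCC1` is not yet measured in this assay. It differs from compound 1 as follows: cyclohexyl in place of 4-hydroxyphenyl on an oxygen next to a carbonyl group. The aromatic group with its hydrogen-bond donor and acceptor is thus exchanged for a saturated carbon ring with neither.

For the measured compounds named here, no step between measured compounds is available for this exchange. Given that the measured variations at this position have all stayed within the scatter, the step from compound 1 to compound 4 is expected to be small, with no direction beyond the scatter favoured. Compound 4 is therefore expected near 22000 nM, within a range of 8000 nM to 60000 nM. The step of a 1.0-fold lower number from compound 1 to compound 4 (0.02 log units; within the scatter) is the estimate this implies.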

Compound 4, half-maximal effective concentration: 22000 nM
Estimate against measurement, compound 4: no gap at the digits printed; low and high end bracket the measured number.
By their numbers in this assay, from the lowest: compounds 3, 4, 1 and 2 (each within the scatter of the next).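

In this assay, for the compounds shown here, the exchange of 4-hydroxyphenyl for cyclohexyl on an oxygen next to a carbonyl group gives a 1.0-fold lower number from compound 1 to compound 4 (0.02 log units; within the scatter) and provides the first step at this position between two compounds that differ in one place. Here, a non-aromatic ring of carbon only, with 0 hydrogen-bond donors and 0 hydrogen-bond acceptors, gives compound 4 at 22000 nM, a number that cannot be told apart from that of compound 1, so neither the aromatic ring nor the hydrogen-bond donor and acceptor of 4-hydroxyphenyl is needed for a number of this size in this pair. Nothing measured here explains why the two numbers cannot be told apart.

A group carrying an amine or a carboxylic acid, or a longer carbon chain, on this oxygen stands outside the four compounds shown, so it remains open whether any group at this position can give a number beyond the scatter. Going by these compounds, how the number responds to a change in the shared core itself also remains open, since all four compounds carry it unchanged.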